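The source may report more compounds than this note shows. Statements on the series, on what has been measured and on what is new or still open speak of the compounds shown alone.

In a functional assay on A549 cells (Homo sapiens) for cytotoxicity, read by MTT assay, with a stated time of 72 h (a higher number here means a weaker inhibitor, a lower number a stronger inhibitor), compound 1 (`COc1ccc(/C=C2\CNC/C(=C\c3ccc(OC)c(OC)c3)C2=O)cc1OC`) gives 2900 nM. That value lies within the scatter of both neighbours: compound 2 (`COc1cc(/C=C2\CN(C)C/C(=C\c3cc(OC)c(OC)c(OC)c3)C2=O)cc(OC)c1OC`) at 1700 nM and compound 3 (`CCN1C/C(=C\c2cc(OC)c(OC)c(OC)c2)C(=O)/C(=C/c2cc(OC)c(OC)c(OC)c2)C1`) at 4200 nM. Compound 4 (`CCN1C/C(=C\c2ccc(OC)c(OC)c2)C(=O)/C(=C/c2ccc(OC)c(OC)c2)C1`) differs from compound 1 by ethyl in place of hydrogen on an amine nitrogen in a ring.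

Among the measured compounds shown here, one measured step bears on this change: a 2.5-fold higher number from compound 2 to compound 3 (0.39 log units; beyond the scatter), modest but beyond the scatter, with methyl in place of hydrogen on a saturated chain carbon bound to an amine nitrogen in a ring. This is only an indirect guide, since that step starts from a substituted nitrogen and its compounds carry other groups than compound 1 does. For the measured compounds named here, no measured pair isolates hydrogen against ethyl on this nitrogen. A small rise in this assay is therefore expected, possibly not beyond the scatter. The expected change is a 1.3-fold higher number from compound 1 to compound 4 (0.12 log units; within the scatter). For compound 4 the estimated value is 3800 nM, with an expected range of 1700 nM to 8000 nM.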

Compound 4, half-maximal inhibitory concentration: 3600 nM
Compound 4: middle estimate off by 1.1-fold (0.02 log units), on the high side, within the range that was stated.
By their numbers in this assay, from the lowest: compounds 2, 1, 4 and 3 (each within the scatter of the next, the first and the last beyond it).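

In this assay, among the compounds shown here, a 1.2-fold higher number from compound 1 to compound 4 (0.09 log units; within the scatter) is the first direct reading of ethyl against hydrogen on this amine nitrogen in a ring, and it lies within the scatter. The earlier step, a 2.5-fold higher number from compound 2 to compound 3 (0.39 log units; beyond the scatter), could not give this reading, as it starts from a nitrogen that already carries methyl and its compounds carry other groups than compound 1 does. With the groups of compound 1, hydrogen on this nitrogen can thus be exchanged for ethyl without a step beyond the scatter, and no measurement at hand accounts for the size of this step.

On these data alone, whether a longer chain, a benzyl group or an acetyl group on this nitrogen stays within the scatter of hydrogen remains open. Also open, as far as these compounds go, is whether a hydroxyethyl chain there would read the same as ethyl.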